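Cytotoxicity notes on aryl variation of the shared core

This account rests on a few compounds, and the source may have more. Where it says the series, first, only, none or still open, it means among the compounds named here.

Compound 1 `COC(=O)c1c(NCCNc2ccnc3cc(Cl)ccc23)noc1-c1ccc([N+](=O)[O-])cc1` gives 3790 nM in an ADME assay on J774.A1 cells (Mus musculus) for cytotoxicity, read by MTT assay, with a stated time of 48 h; on this read-out higher numbers stand for lower toxicity in this test and lower numbers for higher toxicity in this test.
Compound 2 `COC(=O)c1c(NCCNc2ccnc3cc(Cl)ccc23)noc1-c1ccccc1F` gives 3420 nM in this assay.

Compound 2 holds the lowest of the two numbers in this assay, with compound 1 nearest: a 1.1-fold lower number from compound 1 to compound 2 (0.04 log units; within the scatter). Compound 3 `COC(=O)c1c(NCCNc2ccnc3cc(Cl)ccc23)noc1-c1ccc(Cl)cc1Cl` differs from compound 2 by 2,4-dichlorophenyl in place of 2-fluorophenyl on an aromatic carbon. For the measured compounds named here, the only measured step that bears on an exchange of this aryl group is the one from compound 1 to compound 2, and it was within the scatter; the step of a 1.0-fold higher number from compound 2 to compound 3 (0.01 log units; within the scatter) is therefore expected to be none beyond the scatter. Compound 3 is estimated at 3500 nM, within 1500 nM to 8000 nM.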

Compound 3, half-maximal cytotoxic concentration: 3450 nM
Compound 3: middle estimate off by 1.0-fold (0.01 log units), on the high side; measured number inside the range.
By their numbers in this assay, from the lowest: compounds 2, 3 and 1 (each within the scatter of the next).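

On the aromatic carbon next to the ring oxygen, 2,4-dichlorophenyl in place of 2-fluorophenyl gives a 1.0-fold higher number from compound 2 to compound 3 (0.00 log units; within the scatter) in this assay, and in place of 4-nitrophenyl it gives a 1.1-fold lower number from compound 1 to compound 3 (0.04 log units; within the scatter). Compound 1, compound 2 and compound 3 thus place three differently substituted phenyl groups at this position within the scatter of one another, which a single step could not show. Nothing available explains why these numbers stay together.

Open, going by these compounds, is whether a phenyl group carrying an amine or a carboxylic acid, or a methyl group in place of the aryl ring, would move the number beyond the scatter. Also open, on these data alone, is the outcome of exchanging the methoxycarbonyl group.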